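The compounds below may be only part of what the source reports. "The series", "measured", "known", "first", "only" and "open" are said of these compounds alone.

Measured compounds:
- compound 1 `CN(C)CCn1cnnc1-c1cc(Oc2ccc(NC(=O)N/N=C/c3ccc(Cl)cc3Cl)cc2F)ccn1`: 130 nM
- compound 2 `CN(C)CCn1cnnc1-c1cc(Oc2ccc(NC(=O)N/N=C/c3ccccc3O[N+](=O)[O-])cc2F)ccn1`: 1270 nM
- compound 3 `CN(C)CCn1cnnc1-c1cc(Oc2ccc(NC(=O)N/N=C/c3ccccc3)cc2F)ccn1`: 1780 nM

All three share one core and differ only in the aryl group on the carbon with a double bond to nitrogen. In a functional assay on NCI-H460 cells (Homo sapiens) for cytotoxicity, read by MTT assay, with a stated time of 72 h (a lower number here means a stronger inhibitor, a higher number a weaker inhibitor), compound 2 sits second highest of the three numbers; its nearest neighbour is compound 3, with a step of a 1.4-fold higher number from compound 2 to compound 3 (0.15 log units; within the scatter) that stays within the scatter, and the furthest is compound 1, whose step is a 9.8-fold higher number from compound 1 to compound 2 (0.99 log units; beyond the scatter). The parallel step a 14-fold higher number from compound 1 to compound 3 (1.14 log units; beyond the scatter) shows the same picture from the other side.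

Compound 4 `CN(C)CCn1cnnc1-c1cc(Oc2ccc(NC(=O)N/N=C/c3cccc(O)c3)cc2F)ccn1` is not yet measured. Its change from compound 2 is 3-hydroxyphenyl in place of 2-(nitrooxy)phenyl on a carbon with a double bond to nitrogen.

Within the data shown here, the step that bears most directly is the one from compound 2 to compound 3, where removing the nitrooxy group left the number within the scatter; the steps from compound 1 point only to the 2,4-dichlorophenyl group being the outlier. Nothing measured speaks to a hydroxyl on this ring. The expectation for compound 4 is therefore no step beyond the scatter, a 1.2-fold higher number from compound 2 to compound 4 (0.07 log units; within the scatter). Compound 4 is estimated at 1500 nM, with a range from 500 nM to 4500 nM.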

Compound 4, half-maximal inhibitory concentration: 780 nM
Estimate against measurement, compound 4: 1.9-fold (0.28 log units) above; the range from low to high includes it.
By their numbers in this assay, from the lowest: compound 1; then compounds 4, 2 and 3 (each within the scatter of the next, the first and the last beyond it).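

In this assay, hydroxy in place of hydrogen on the aromatic ring gives a real if modest shift at this position (a 2.3-fold lower number from compound 3 to compound 4 (0.36 log units; beyond the scatter)), whereas removing nitrooxy did not move the number beyond the scatter. The exchange of 2-(nitrooxy)phenyl for 3-hydroxyphenyl stays within the scatter (a 1.6-fold lower number from compound 2 to compound 4 (0.21 log units; within the scatter)), so these two groups cannot be ordered, although they differ in size and in hydrogen-bond donors and acceptors. The 2,4-dichlorophenyl group remains clearly apart (a 6.0-fold higher number from compound 1 to compound 4 (0.78 log units; beyond the scatter)), and the hydroxy group recovers only a small part of that distance. No measurement at hand gives a reason for these differences. Open, as far as these compounds go, are whether the hydroxy step depends on where the group sits on the ring, and whether a single chlorine, an amine or a carboxylic acid on this ring would come closer to compound 1.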